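A few compounds are considered here, and "the series" means these few. Any claim that something is new, unique, unknown or untested is made for them only; others in the source may bear on it.

Values in a functional assay on HL-60 cells (Homo sapiens) for cytotoxicity, read by MTT assay, with a stated time of 96 h; on this read-out lower numbers stand for stronger inhibition and higher numbers for weaker inhibition:
- compound 1 `CC[C@H](N)C(=O)N[C@@H]1C(=O)N2[C@@H](CC[C@@H]1CCN)CC[C@H]2C(=O)NC(c1ccccc1)c1ccccc1`: 25000 nM
- compound 2 `CC[C@H](NC)C(=O)N[C@@H]1C(=O)N2[C@@H](CC[C@@H]1CCN)CC[C@H]2C(=O)NC(c1ccccc1)c1ccccc1`: 31000 nM
- compound 3 `CC[C@H](N)C(=O)N[C@@H]1C(=O)N2[C@@H](CC[C@@H]1CCO)CC[C@H]2C(=O)NC(c1ccccc1)c1ccccc1`: > 100000 nM (a limit)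

Within the data shown here, compound 2 stands level with its only numeric neighbour: a 1.2-fold higher number from compound 1 to compound 2 (0.09 log units; within the scatter). That step methylates an amine nitrogen outside the 2-aminoethyl chain.

Compound 4 `CC[C@H](NC)C(=O)N[C@@H]1C(=O)N2[C@@H](CC[C@@H]1CCNC(=O)c1ccccc1)CC[C@H]2C(=O)NC(c1ccccc1)c1ccccc1` differs at that chain, which becomes 2-benzamidoethyl: benzoyl in place of hydrogen on an amine nitrogen. Among the measured compounds shown here, the only measured change on this chain replaces amino with hydroxy: an at least 4.0-fold higher number from compound 1 to compound 3 (0.60 log units; beyond the scatter). It hints at a rise in this assay, but a hydroxy group is a weak guide to a benzoyl group, so no step beyond the scatter is expected, with wide uncertainty either way. The expected step is a 1.0-fold lower number from compound 2 to compound 4 (0.01 log units; within the scatter). For compound 4 the estimate is 30000 nM, expected within 6000 nM to 100000 nM.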

Compound 4, half-maximal inhibitory concentration: 32600 nM
Beside the measured number, compound 4's estimate is 1.1-fold (0.04 log units) below it, and the stated range covers the measured number.
By their numbers in this assay, from the lowest: compounds 1, 2 and 4 (each within the scatter of the next). At a limit, above all of these: compound 3.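

In this assay, benzoyl on the amine nitrogen of the chain gives a 1.1-fold higher number from compound 2 to compound 4 (0.02 log units; within the scatter). The 2-benzamidoethyl chain of compound 4 thus reads level with the 2-aminoethyl chain, so a free amino group is not needed on this chain to hold that level, whereas hydroxy in place of amino gave an at least 4.0-fold higher number from compound 1 to compound 3 (0.60 log units; beyond the scatter). Compound 3 remains a limit of the assay: the limit of > 100000 nM in this assay, at which 1 of the 4 values shown sits.

Open: whether acetyl or methanesulfonyl on this nitrogen reads like benzoyl, and whether a carboxylic acid at the chain end reads like hydroxy. The hydroxy and benzoyl steps also start from different compounds, so they are not a matched pair.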